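The compounds below may be only part of what the source reports. "The series", "measured", "known", "first", "only" and "open" are said of these compounds alone.

Compound 1 `CSC(=S)N[C@H]1CCOC1=O` gives > 128000 nM in a functional assay on MGC-803 cells (Homo sapiens) for cytotoxicity, read by MTT assay, with a stated time of 72 h; on this read-out higher numbers stand for weaker inhibition and lower numbers for stronger inhibition; this value is a limit.
Compound 2 `CCCCCCSC(=S)N[C@H]1CCOC1=O` gives > 128000 nM; this value is a limit.

Compound 2 therefore stands at the upper edge of what this assay reports, with no number of its own. Within the data shown here, the one step measured, a step that the two limits leave unreadable from compound 1 to compound 2, cannot be sized because of the limit of > 128000 nM in this assay, at which 2 of the 2 values shown sit. Compound 3 `CCCCCCCCCCCCSC(=S)N[C@H]1CCOC1=O` differs from compound 2 by hexyl in place of hydrogen on a saturated chain carbon, six bonds along the chain from a sulfur. Among the measured compounds shown here, the only step that bears on this change is the unreadable one from compound 1 to compound 2, so no direction or size can be drawn from it, and nothing in the data shows that lengthening the chain moves the read-out in this assay. Compound 3 is thus expected to remain near the limit, with an estimate of 100000 nM and a range of 30000 nM to 300000 nM. The expected step is an at least 1.2-fold lower number from compound 2 to compound 3 (0.10 log units; that floor lies within the scatter), which is an estimate only.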

Compound 3, half-maximal inhibitory concentration: 33300 nM
The estimate for compound 3 lay 3.0-fold (0.48 log units) above the measured number; low and high end bracket the measured number.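

In this assay, hexyl in place of hydrogen on a saturated chain carbon, six bonds along the chain from a sulfur, gives the only readable step among the compounds shown, an at least 3.8-fold lower number from compound 2 to compound 3 (0.58 log units; beyond the scatter), whereas the step from compound 1 to compound 2 cannot be read. Compound 3 is the only one of the three with a number of its own, so this position does respond to a change in the chain, which the earlier pair could not show. As far as these compounds go, the full size of the step stays unknown because it starts from a limit: the limit of > 128000 nM in this assay, at which 2 of the 3 values shown sit.

A single readable step sets no trend with chain length. From the compounds shown here alone, whether a longer chain, or a chain carrying an amine or a carboxylic acid, would lower the number further remains open.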